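This account rests on a few compounds, and the source may have more. Where it says the series, first, only, none or still open, it means among the compounds named here.

Measured compounds:

Compound 1 `CC(=O)Oc1ccc(/C=C/C(=O)OCCSc2nc(-c3ccc(S(C)(=O)=O)cc3)n(-c3ccc(C(F)(F)F)cc3)n2)cc1OC(C)=O` — 11300 nM
Compound 2 `COc1cc(/C=C/C(=O)OCCSc2nc(-c3ccc(S(C)(=O)=O)cc3)n(-c3ccc(C(F)(F)F)cc3)n2)ccc1OC(C)=O` — 10800 nM

In a functional assay on Caco-2 cells (Homo sapiens) for antiproliferative activity, read by MTT assay, with a stated time of 72 h (a lower number here means a stronger inhibitor, a higher number a weaker inhibitor), compound 1 gives 11300 nM, and compound 2 gives 10800 nM. Compound 2 thus stands alongside compound 1, the two numbers within the scatter of each other, so neither can be called stronger or weaker. Among the measured compounds shown here, the only step measured so far, a 1.0-fold lower number from compound 1 to compound 2 (0.02 log units; within the scatter), changed nothing beyond the scatter.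

Compound 3 `COc1cc(/C=C/C(=O)OCCSc2nc(-c3ccc(S(C)(=O)=O)cc3)n(-c3ccc(C(F)(F)F)cc3)n2)ccc1O` is the next compound in this line. It differs from compound 2 in one place: hydrogen in place of acetyl on an oxygen on an aromatic ring. For the measured compounds named here, the one step that bears on this change is a 1.0-fold lower number from compound 1 to compound 2 (0.02 log units; within the scatter), which swapped a group on the same oxygen without moving the number. On that basis no step beyond the scatter is expected in this assay. The expected step is a 1.1-fold lower number from compound 2 to compound 3 (0.03 log units; within the scatter). Compound 3 is therefore estimated to give 10000 nM in this assay. The range of that estimate for compound 3 runs from 4500 nM to 25000 nM.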

Compound 3, half-maximal inhibitory concentration: 9050 nM
For compound 3 the middle estimate is 1.1-fold (0.04 log units) above the measured one; the measured number falls inside the stated range.
By their numbers in this assay, from the lowest: compounds 3, 2 and 1 (each within the scatter of the next).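

Going from 4-acetoxy-3-methoxyphenyl to 4-hydroxy-3-methoxyphenyl removes the acetyl altogether and leaves a free hydroxy, a larger change than swapping one group on an oxygen for another. Even so, in this assay the number barely moves (a 1.2-fold lower number from compound 2 to compound 3 (0.08 log units; within the scatter)), so among the compounds shown, this oxygen gives the same reading with or without its acetyl. No supporting data are available to explain this lack of change.

The compounds shown leave open whether anything placed here could move the number beyond the scatter, such as a longer ether chain like butoxy, or an amine in place of the hydroxy. A single step also cannot show whether the hydroxy would matter as little on a compound with a different group on the other ring oxygen.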